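From Methylsulfanyl to Propylamino on a Weakly Inhibiting Core

The compounds below may be only part of what the source reports. "The series", "measured", "known", "first", "only" and "open" are said of these compounds alone.

Measured so far:
compound 1 `CSc1nc2cc(Cl)c(Cl)cc2n1[C@@H]1O[C@H](CO)[C@@H](O)[C@H]1O` — > 100000 nM
compound 2 `C[C@H]1O[C@@H](n2c(Cl)nc3cc(Cl)c(Cl)cc32)[C@H](O)[C@@H]1O` — 75000 nM

Of the compounds shown here, two have been tested in a functional assay on KB cells (Homo sapiens) for inhibition; on this read-out higher numbers stand for weaker inhibition and lower numbers for stronger inhibition. Compound 1 reaches only a limit of this assay, > 100000 nM, so no number is known for it; (the limit of > 100000 nM in this assay, at which 1 of the 2 values shown sits). Compound 2 gives 75000 nM in this assay. Among the compounds with values here, no step between the two is computed, and the two values show only that both compounds inhibit weakly.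

The next compound, compound 3 `CCCNc1nc2cc(Cl)c(Cl)cc2n1[C@@H]1O[C@H](CO)[C@@H](O)[C@H]1O`, is built from compound 1 by one change: propylamino in place of methylsulfanyl on an aromatic carbon. With compound 1 sitting at a limit, the size of the step of an at least 1.2-fold lower number from compound 1 to compound 3 (0.09 log units; that floor lies within the scatter) that is expected can be judged only roughly, and nothing measured here points to a strong gain. Compound 3 is expected to stay in the weak range, with an estimate of 80000 nM and a likely span from 20000 nM to 300000 nM.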

Compound 3, half-maximal inhibitory concentration: > 100000 nM
Compound 3: no number, only a limit (the forecaster's own chance of this, stated with the estimate: 50%); at least 1.2-fold (0.09 log units) between middle value and limit.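

Within the data shown here, compound 1 and compound 3 both stop at a limit of this assay, so no step between them can be read: (the limit of > 100000 nM in this assay, at which 2 of the 3 values shown sit). The compounds shown leave open whether propylamino in place of methylsulfanyl on an aromatic carbon changes inhibition at all.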